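At the limit: a chlorine moved on the benzyl ring

The source may hold more compounds than are shown below. What is called first, only, known or untested is meant among the compounds shown, and "the series" means these compounds.

Two compounds of a shared core have been examined in an ADME assay on A549 cells (Homo sapiens) for inhibition, read by MTT assay; a higher number here means a weaker inhibitor of growth, a lower number a stronger inhibitor of growth. Compound 1, `Cc1nc(-c2ccc(F)cc2)oc1-c1csc(Cc2ccc(F)cc2)n1`, gives > 250 ug/mL in this assay, a limit of the assay rather than a number. Compound 2, `Cc1nc(-c2ccccc2)oc1-c1csc(Cc2ccc(Cl)cc2)n1`, likewise reaches only a limit in this assay, at > 250 ug/mL. Within the data shown here, compound 2 thus stands at the limit of > 250 ug/mL in this assay, at which 2 of the 2 values shown sit, and no step between measured compounds can be read from these two values. Compound 3, `Cc1nc(-c2ccccc2)oc1-c1csc(Cc2cccc(Cl)c2)n1`, has not yet been measured. It differs from compound 2 by 3-chlorophenyl in place of 4-chlorophenyl on a saturated chain carbon bound to an aromatic carbon. Among the measured compounds shown here, no measured step exists to lean on, and both known values rest at the limit, so the step expected in this assay is a number no higher from compound 2 to compound 3 (the limit leaves the size open), nothing beyond the scatter. Compound 3 is estimated at 250 ug/mL in this assay, with a range from 100 ug/mL to 600 ug/mL, and it is expected that the assay will most likely again report only a limit.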

Compound 3, concentration for 50% growth inhibition: > 250 ug/mL
Compound 3: no number, only a limit; the forecaster's own chance of this, stated with the estimate: 80%; the middle value lies on the limit itself.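

Compound 3 also reaches only a limit in this assay, so the step between compound 2 and compound 3 cannot be read: the limit of > 250 ug/mL in this assay, at which 3 of the 3 values shown sit.

With no number among them, the compounds shown leave open whether 4-chlorobenzyl and 3-chlorobenzyl differ at all in this assay.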